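The source may hold more compounds than are shown below. What is called first, only, known or untested is meant among the compounds shown, and "the series" means these compounds.

Two related compounds have been tested so far in an ADME assay on microsomes from liver (Rattus norvegicus) for metabolic stability, read by mass spectrometry, using NADPH, with a stated time of 10 min; a lower number here means that less of the compound is left, a higher number that more of the compound is left. There, compound 1 (`CCCCc1[nH]c(=O)c(-c2nnc(Cc3cccc(Cl)c3)o2)c(O)c1-c1c(OC)cccc1OC`) gives 38%, and compound 2 (`COc1cccc(OC)c1-c1c(C2CC2)[nH]c(=O)c(-c2nnc(Cc3ccc(Cl)cc3)o2)c1O`) gives 51%. Compound 1 therefore holds the lower of the two numbers, and the gap lies beyond the usual scatter. These two compounds differ in more than one place, so their gap does not show what a single change does. Compound 3 (`CCCCc1[nH]c(=O)c(-c2nnc(Cc3ccccc3Cl)o2)c(O)c1-c1c(OC)cccc1OC`) differs from compound 1 in one place only: 2-chlorophenyl in place of 3-chlorophenyl on a saturated chain carbon bound to an aromatic carbon. Here 2-chlorophenyl stands in place of 3-chlorophenyl on a saturated chain carbon bound to an aromatic carbon. The atoms stay the same and are only joined differently, so with compound 1 at 38% as the starting point, no change beyond the scatter is expected in either direction. The expected step, a number 2 percentage points higher from compound 1 to compound 3 (within the scatter), is small. In this assay, compound 3 is expected at 40%, with an estimated range from 25% to 55%.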

Compound 3, percent of the compound remaining: 24%
Estimate against measurement, compound 3: 16 percentage points above; measured number below the stated range.
By their numbers in this assay, from the lowest: compound 3; then compound 1; then compound 2.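

Among the compounds shown here, changing 3-chlorophenyl to 2-chlorophenyl on a saturated chain carbon bound to an aromatic carbon gives a number 14 percentage points lower from compound 1 to compound 3 (beyond the scatter) in this assay and is the first single change that can be read in this set. The two groups have the same atoms and the same counts, so the result shows that this position can respond to where the chlorine sits on the phenyl ring, even when nothing is added or removed. No measurement shown here explains why the number moves in this direction.

Compound 2 differs from compound 1 and compound 3 in more than one place, so it cannot show how its own chlorophenyl group compares on the same core. Also open, from the compounds shown here alone, is how a plain phenyl or a 2-fluorophenyl would behave at this position on the core of compound 1.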